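From 4-chlorophenyl to 2-chlorophenyl on a sulfur

A few compounds are considered here, and "the series" means these few. Any claim that something is new, unique, unknown or untested is made for them only; others in the source may bear on it.

Compound 1 `COc1ccc(Sc2cn(-c3ccc4c(c3)B(O)OC4)c3ccccc23)cc1`: > 10 ug/mL (a limit)
Compound 2 `O=[N+]([O-])c1ccc(Sc2cn(-c3ccc4c(c3)B(O)OC4)c3ccccc23)cc1`: > 10 ug/mL (a limit)
Compound 3 `OB1OCc2ccc(-n3cccc3Sc3ccc(Cl)cc3)cc21`: > 10 ug/mL (a limit)

All three compounds were tested in an ADME assay on L929 cells (Mus musculus) for cytotoxicity, read by resazurin assay, with a stated time of 72 h (on this read-out lower numbers stand for stronger inhibition and higher numbers for weaker inhibition), and none has yet given an actual number. For compound 3 the result is > 10 ug/mL, which is a limit and not a number. Among the compounds with values here, the series so far shows one outcome: the limit of > 10 ug/mL in this assay, at which 3 of the 3 values shown sit. Compound 4 `OB1OCc2ccc(-n3cccc3Sc3ccccc3Cl)cc21` has the same atoms as compound 3, joined differently: 2-chlorophenyl in place of 4-chlorophenyl on a sulfur. Within the data shown here, the only measured step, a step that the two limits leave unreadable from compound 1 to compound 2, involves a different change and gives no size to draw on. No step beyond the usual scatter is therefore expected in this assay, in either direction. The expected step is a step that the limit leaves unreadable from compound 3 to compound 4. The estimate for compound 4 is 14 ug/mL, with an expected range of 6 ug/mL to 35 ug/mL.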

Compound 4, half-maximal inhibitory concentration: > 10 ug/mL
Compound 4: only a limit was reported (the forecaster's own chance of this, stated with the estimate: 75%); the middle value lies beyond the limit too.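

Compound 3 and compound 4 both gave only a limit, so no step can be read between them. The compounds shown leave open how far any of them lies beyond that shared outcome: the limit of > 10 ug/mL in this assay, at which 4 of the 4 values shown sit.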